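The compounds below may be only part of what the source reports. "The series", "measured", "known", "first", "only" and "open" are said of these compounds alone.

In a functional assay on NIH3T3 cells (Mus musculus) (on this read-out lower numbers stand for an effect already at smaller amounts and higher numbers for an effect only at larger amounts of compound), compound 1 `Cn1cncc1C(OCc1nc(N2CCC(C(N)=O)CC2)c(C#N)cc1-c1cccc(Cl)c1)c1ccc(C#N)cc1` gives 1.5 nM, while compound 2 `Cn1cncc1C(OCc1nc(N2CCC(O)CC2)c(C#N)cc1-c1cccc(Cl)c1)c1ccc(C#N)cc1` gives 3.6 nM, the higher of the two numbers. Going by the values given here, compound 3 `CN1CCN(c2nc(COC(c3ccc(C#N)cc3)c3cncn3C)c(-c3cccc(Cl)c3)cc2C#N)CC1` has no measurement yet and differs from compound 2 by 4-methylpiperazin-1-yl in place of 4-hydroxypiperidin-1-yl on an aromatic carbon. Among the compounds with values here, only one measured step bears on this change: a 2.4-fold higher number from compound 1 to compound 2 (0.38 log units; beyond the scatter), a modest shift from replacing carbamoyl with hydroxy on a saturated ring carbon. That single step is thin evidence, so the expected step, a 1.2-fold lower number from compound 2 to compound 3 (0.08 log units; within the scatter), is small, with no firm direction and no change expected beyond the scatter. For compound 3, the estimated value is 3 nM, within an expected range of 1 nM to 10 nM.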

Compound 3, half-maximal effective concentration: 2 nM
Beside the measured number, compound 3's estimate is 1.5-fold (0.18 log units) above it, within the range that was stated.
By their numbers in this assay, from the lowest: compounds 1, 3 and 2 (each within the scatter of the next, the first and the last beyond it).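

Replacing 4-hydroxypiperidin-1-yl on this aromatic carbon next to the ring nitrogen with 4-methylpiperazin-1-yl gives a 1.8-fold lower number from compound 2 to compound 3 (0.26 log units; within the scatter) in this assay. Replacing 4-carbamoylpiperidin-1-yl there gives a 1.3-fold higher number from compound 1 to compound 3 (0.12 log units; within the scatter), so compound 3 cannot be told apart from either neighbour, even though the hydrogen-bond donor of 4-hydroxypiperidin-1-yl is gone. Nothing available explains this result. Still open, on these data alone, is how an open-chain group such as dimethylamino, or a carboxylic acid on the piperidine ring, would behave at this position.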